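Diaryl urea series: saturating the alkyne linker of compound 2

The source may report more compounds than this note shows. Statements on the series, on what has been measured and on what is new or still open speak of the compounds shown alone.

The set is three measured ureas and one to be tested, all read in a functional assay on A-375 cells (Homo sapiens) for inhibition, read by MTT assay, with a stated time of 120 h; a lower number here means a stronger inhibitor, a higher number a weaker inhibitor. Among the compounds with values here, compound 1 `CC(NC(=O)/C=C/Oc1ccc(NC(=O)Nc2cc(C(F)(F)F)ccc2Cl)cc1)c1ccccc1` gives 16000 nM and is the only member with a number rather than a limit. Compound 2 `CNC(=O)C#Cc1ccc(NC(=O)Nc2ccc(Cl)c(C(F)(F)F)c2)cc1` reaches only a limit, > 50000 nM, so its true value is not known. Compound 3 `C/C(=C\C(=O)NC(C)c1ccccc1)c1ccc(NC(=O)Nc2ccc(Cl)c(C(F)(F)F)c2)cc1` likewise returns only a limit, > 50000 nM. Within the data shown here, compound 2 thus stands at the top end of what the assay reports, together with compound 3, as noted in the limit of > 50000 nM in this assay, at which 2 of the 3 values shown sit; no step between two numbers can be drawn from it.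

Compound 4 `CNC(=O)CCc1ccc(NC(=O)Nc2ccc(Cl)c(C(F)(F)F)c2)cc1` is the next member. It differs from compound 2 in one place: 2-(methylcarbamoyl)ethyl in place of 2-(methylcarbamoyl)ethynyl on an aromatic carbon. The remainder of the urea and the substituted aryl ring is unchanged.

Among the measured compounds shown here, with compound 2 at a limit, no measured step shows what such a change does, and the change is small in atom count. The expectation for this assay is therefore a shift of unknown sign that may well stay within the scatter, with a good chance that compound 4 also returns only a limit. The estimated value for compound 4 is 45000 nM, within 15000 nM to 150000 nM, which would mean a step of an at least 1.1-fold lower number from compound 2 to compound 4 (0.04 log units; that floor lies within the scatter).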

Compound 4, half-maximal inhibitory concentration: 25200 nM
Estimate against measurement, compound 4: 1.8-fold (0.25 log units) above; the measured number falls inside the stated range.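

In this assay, within the data shown here, 2-(methylcarbamoyl)ethyl in place of 2-(methylcarbamoyl)ethynyl on the aromatic carbon gives an at least 1.9-fold lower number from compound 2 to compound 4 (0.29 log units; that floor lies within the scatter), the first step that can be read at all. The two groups match in heavy atoms, donors and acceptors as counted, so the triple bond is the only counted difference, and with it gone this position yields a number in compound 4 rather than a limit. The true size of the step stays unknown because compound 2 sits at a limit and only a floor can be given: the limit of > 50000 nM in this assay, at which 2 of the 4 values shown sit.

Since that floor lies within the scatter, the compounds shown do not establish that removing the triple bond changes the read-out by more than repeat measurements would. Also open, from the compounds shown here alone, is how this position responds to other groups, such as a longer chain, a carboxylic acid or an amine in place of the methylcarbamoyl end, and whether a double bond in the chain would behave like the ethyl or the ethynyl link.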